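The compounds below may be only part of what the source reports. "The series", "measured", "known", "first", "only" and "open" are said of these compounds alone.

Working notes on the series. Compound 1 `Cc1cc(C)c(NC(=O)N(Cc2ccc(-c3ccccc3)s2)C2CCCCCC2)c(C)c1` carries a phenyl-substituted thiophene on the benzylic arm of the shared core. In a functional assay on a cell-free system (plasma) with sterol O-acyltransferase, Soat (Rattus norvegicus) as the target (on this read-out higher numbers stand for an effect only at larger amounts of compound and lower numbers for an effect already at smaller amounts), compound 1 gives < 1 mg/kg, which is a limit of the measurement and not a number. Compound 3 `Cc1cc(C)c(NC(=O)N(Cc2cccc(-c3nnn(C)n3)c2)C2CCCCCC2)c(C)c1` carries a methyl-tetrazolyl group on the benzylic ring. In this assay compound 3 gives < 1 mg/kg, again a limit. Compound 2 `Cc1cc(C)c(NC(=O)N(Cc2ccc(-c3n[nH]c(C)n3)cc2)C2CCCCCC2)c(C)c1` carries a 5-methyl-1H-1,2,4-triazol-3-yl group. In this assay compound 2 gives > 1 mg/kg, also a limit. Compound 2 therefore stands apart from the other two, which sit at the limit of < 1 mg/kg in this assay, at which 2 of the 3 values shown sit, whereas compound 2 alone sits at the limit of > 1 mg/kg in this assay, at which 1 of the 3 values shown sits. For the measured compounds named here, no single-change step between measured compounds is available.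

Compound 4 `Cc1cc(C)c(NC(=O)N(Cc2ccc(-n3cccn3)cc2)C2CCCCCC2)c(C)c1` differs from compound 2 in one place: 1H-pyrazol-1-yl in place of 5-methyl-1H-1,2,4-triazol-3-yl on an aromatic carbon. Going by the values given here, no measured step covers this change. The expected step from compound 2 to compound 4 is a number no higher from compound 2 to compound 4 (the limit leaves the size open), a modest move toward smaller doses, close to the scatter. For compound 4 the estimate in this assay is 1 mg/kg, with a range from 0.3 mg/kg to 3 mg/kg.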

Compound 4, dose for half-maximal effect: > 1 mg/kg
Compound 4 was reported as a limit; the forecaster's own chance of this, stated with the estimate: 60%; the middle value sits exactly at the limit.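

Compound 2 and compound 4 are both reported as limits in this assay, and no step can be read between them. The compounds shown leave open how far apart the two lie, and whether 1H-pyrazol-1-yl and 5-methyl-1H-1,2,4-triazol-3-yl differ on this read-out at all.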